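A few compounds are considered here, and "the series" means these few. Any claim that something is new, unique, unknown or untested is made for them only; others in the source may bear on it.

Measured compounds:
compound 1, `N#Cc1cnc(NCc2cnccc2C(F)(F)F)cc1NC[C@H]1C[C@@H](O)C1`, 4200 nM
compound 2, `N#Cc1cnc(NCc2cnccc2C(F)(F)F)cc1NC1CCOCC1`, 9800 nM

Of the compounds shown here, two sharing one core have been measured in an assay on isolated protein for inhibition of protein kinase C delta type (Homo sapiens), read by TR-FRET, with a stated time of 2 h; a higher number here means a weaker inhibitor, a lower number a stronger inhibitor. Compound 1 gives 4200 nM. Among the measured compounds shown here, compound 2 gives 9800 nM, the higher of the two numbers; the only measured step, a 2.3-fold higher number from compound 1 to compound 2 (0.37 log units; beyond the scatter), separates it from compound 1.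

Compound 3, `N#Cc1cnc(NCc2cnccc2C(F)(F)F)cc1N[C@H]1CC[C@@H](C(N)=O)CC1`, has not yet been measured in this assay. It differs from compound 2 in one place: 4-carbamoylcyclohexyl in place of oxan-4-yl on a nitrogen on an aromatic ring. For the measured compounds named here, the single measured step that bears on this position, a 2.3-fold higher number from compound 1 to compound 2 (0.37 log units; beyond the scatter), shows that exchanging the group on this nitrogen shifts the number only modestly, and that the oxan-4-yl group of compound 2 is the weaker of the two options seen. Since compound 3 again replaces that oxan-4-yl group, a shift back toward a lower number of about the same modest size is the most that the data support. Compound 3 is therefore expected to give 5000 nM, within a range of 1500 nM to 16000 nM, an expected step of a 2.0-fold lower number from compound 2 to compound 3 (0.29 log units; within the scatter) from compound 2.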

Compound 3, half-maximal inhibitory concentration: 400 nM
Beside the measured number, compound 3's estimate is 13-fold (1.10 log units) above it; measured number below the stated range.
By their numbers in this assay, from the lowest: compound 3; then compound 1; then compound 2.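

In this assay, the group on this nitrogen turns out to be able to move the number by a large margin, not only a modest one: the change to 4-carbamoylcyclohexyl gives a 25-fold lower number from compound 2 to compound 3 (1.39 log units; beyond the scatter), and the same group measured against (3-hydroxycyclobutyl)methyl gives an 11-fold lower number from compound 1 to compound 3 (1.02 log units; beyond the scatter). Set against oxan-4-yl, the entering group brings a six-membered ring of carbon only, a double bond outside aromatic rings, a hydrogen-bond donor and two defined stereocentres, so this single step changes several features at once and cannot assign the gain to any one of them. No measurement is available that explains why this group gives the lowest number of the three.

On these data alone, whether the gain belongs to the carbamoyl group or to the cyclohexyl ring remains open, and a plain cyclohexyl, or a cyclohexyl carrying a carboxylic acid or an amine in place of the carbamoyl group, would be needed to tell these apart. Also open, as far as these compounds go, are whether the other stereoisomer of 4-carbamoylcyclohexyl gives a similar number and whether the large step holds when other parts of the shared core change.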